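Series notes: from compound 2 to compound 3

The compounds below may be only part of what the source reports. "The series", "measured", "known", "first", "only" and "open" are said of these compounds alone.

Measured in a functional assay on RT16 cells (Cricetulus griseus) for inhibition, read by CellTiter-Blue, with a stated time of 96 h; a higher number here means a weaker inhibitor, a lower number a stronger inhibitor
- compound 1 `Nc1nc2[nH]c(CCCCCCCCC(=O)N[C@@H](CCC(=O)O)C(=O)O)cc2c(=O)[nH]1` 12.3 nM
- compound 2 `Nc1nc2[nH]c(CCCCCCC(=O)O)cc2c(=O)[nH]1` > 1000 nM

Compound 2 stands at a limit of this assay (> 1000 nM) and not at a number. Of the two compounds, only compound 1 gives a number (12.3 nM) in these notes.

Compound 3 `Nc1nc2[nH]c(CCCCCCCCC(=O)O)cc2c(=O)[nH]1` is the next entry. The change from compound 2 is 2-carboxyethyl in place of carboxy on a saturated chain carbon, six bonds along the chain from an aromatic carbon and reads, in words, as 2-carboxyethyl in place of carboxy on a saturated chain carbon, six bonds along the chain from an aromatic carbon. Among the measured compounds shown here, no measured step shows what this change does. The expected step that the limit leaves unreadable from compound 2 to compound 3 in this assay is therefore none beyond the scatter, with no direction favoured. For compound 3 the estimated value is 1500 nM, within an expected range of 300 nM to 6000 nM and with a good chance of another limit.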

Compound 3, half-maximal inhibitory concentration: > 10000 nM
Compound 3 ended at the assay's limit (the forecaster's own chance of this, stated with the estimate: 70%); middle value at least 6.6-fold (0.82 log units) from the limit.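

In this assay compound 3 gives no number but a limit: the limit of > 10000 nM in this assay, at which 1 of the 3 values shown sits.

Among the compounds shown here, with the chain of compound 3 held fixed, hydroxy in place of (1,3-dicarboxypropyl)amino on a carbonyl carbon gives an at least 810-fold higher number from compound 1 to compound 3 (2.91 log units; beyond the scatter), beyond the scatter and the first readable step. The extension from carboxy to 2-carboxyethyl cannot be read, as compound 2 and compound 3 both stand at limits, so the longer chain ending in a free carboxylic acid shows no measurable gain here.

On these data alone, whether (1,3-dicarboxypropyl)amino would also give a number on the shorter chain of compound 2 remains open. Also open, as far as these compounds go, is which part of that group carries the step, for instance whether a simple amide or an amine-bearing group on the same carbonyl carbon would hold any of it, and what a longer chain would do.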